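This account rests on a few compounds, and the source may have more. Where it says the series, first, only, none or still open, it means among the compounds named here.

Compound 1, `CC1(C)[C@H]2CC[C@]1(C)N(Cc1cn(-c3ccccc3Br)nn1)C(=O)C2`, carries a bromo group on a six-membered aromatic ring of carbon only. In a functional assay on LoVo cells (Homo sapiens) for inhibition, read by MTT assay, with a stated time of 24 h (a higher number here means a weaker inhibitor, a lower number a stronger inhibitor), compound 1 gives 60 nM. Compound 2, `CC1(C)[C@H]2CC[C@]1(C)N(Cc1cn(-c3ccccc3F)nn1)C(=O)C2`, gives 40 nM in this assay, and compound 3, `CC1(C)[C@H]2CC[C@]1(C)N(Cc1cn(-c3ccccc3O)nn1)C(=O)C2`, gives 540 nM. Of these three numbers compound 1 stands second highest: the step of a 1.5-fold lower number from compound 1 to compound 2 (0.18 log units; within the scatter) stays within the scatter, while a 9.0-fold higher number from compound 1 to compound 3 (0.95 log units; beyond the scatter) lies beyond it.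

Compound 4, `Cc1ccccc1-n1cc(CN2C(=O)C[C@@H]3CC[C@@]2(C)C3(C)C)nn1`, differs from compound 1 in one place: methyl in place of bromo on an aromatic carbon. For the measured compounds named here, two measured steps bear on this exchange. Putting fluoro in place of bromo, a 1.5-fold lower number from compound 1 to compound 2 (0.18 log units; within the scatter), changed little, whereas putting hydroxy in place of bromo, a 9.0-fold higher number from compound 1 to compound 3 (0.95 log units; beyond the scatter), weakened inhibition markedly. Methyl, like bromo and fluoro and unlike hydroxy, is counted with no hydrogen-bond donor and no hydrogen-bond acceptor. In this assay no step beyond the scatter is expected for this change. Compound 4 is therefore expected to give 60 nM, within a range from 25 nM to 150 nM. The expected step is no change at the digits printed from compound 1 to compound 4 (within the scatter).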

Compound 4, half-maximal inhibitory concentration: 80 nM
For compound 4 the middle estimate is 1.3-fold (0.12 log units) below the measured one; measured number inside the range.
By their numbers in this assay, from the lowest: compounds 2, 1 and 4 (each within the scatter of the next); then compound 3.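

At this place on the ring, methyl behaves much like the two halogens: with methyl in place of bromo, a 1.3-fold higher number from compound 1 to compound 4 (0.12 log units; within the scatter) stays within the scatter, and with methyl in place of fluoro, a 2.0-fold higher number from compound 2 to compound 4 (0.30 log units; within the scatter) does too. So a carbon group, and not only a halogen, fits this picture, and among the four groups only hydroxy stands apart in this assay, with methyl in place of hydroxy giving a 6.8-fold lower number from compound 3 to compound 4 (0.83 log units; beyond the scatter). Nothing given here explains why these three groups read alike or why hydroxy differs.

As far as these compounds go, it remains open whether a longer chain such as ethyl, or a methoxy group, would stay with methyl and the halogens. From the compounds shown here alone, it is also open whether an amine or a carboxylic acid at this place would fall with hydroxy.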